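Amino in place of the chain on compound 2

A few compounds are considered here, and "the series" means these few. Any claim that something is new, unique, unknown or untested is made for them only; others in the source may bear on it.

In a functional assay on the whole organism (stomach) with Rattus norvegicus as the target (a higher number here means that more compound is needed for the effect, a lower number that less compound is needed), compound 2 (`CN(C)CC/N=C(\S)C1(c2ccccn2)CCCS1`) gives > 30 mg/kg as a limit and not a number. Compound 1 (`OCC/N=C(\S)C1(c2ccccn2)CCCS1`) gives > 30 mg/kg as a limit too. Compound 2 therefore stands at the limit of > 30 mg/kg in this assay, at which 2 of the 2 values shown sit, and has no number of its own. Among the compounds with values here, the one measured step is a step that the two limits leave unreadable from compound 1 to compound 2 and offers no size to carry over. The change to compound 3 (`N/N=C(\S)C1(c2ccccn2)CCCS1`) is amino in place of 2-(dimethylamino)ethyl on a double-bonded nitrogen and puts amino in place of 2-(dimethylamino)ethyl on a double-bonded nitrogen. No direction can be read, so the expected step that the limit leaves unreadable from compound 2 to compound 3 is tentative and a further limit seems likely. In this assay compound 3 is estimated at 40 mg/kg with an expected range of 12 mg/kg to 100 mg/kg for now.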

Compound 3, dose for half-maximal effect: > 30 mg/kg
Compound 3 was reported as a limit; the forecaster's own chance of this, stated with the estimate: 70%; the middle value does not contradict the limit.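

No new step can be read between compound 3 and compound 1 or compound 2, because all three stand at a limit and not a number: the limit of > 30 mg/kg in this assay, at which 3 of the 3 values shown sit.

The compounds shown leave open how amino, 2-hydroxyethyl and 2-(dimethylamino)ethyl on the double-bonded nitrogen compare with one another.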